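Pyrrolidinyl in place of dimethylamino on the shared core

The source may hold more compounds than are shown below. What is called first, only, known or untested is meant among the compounds shown, and "the series" means these compounds.

Compound 2 `CN(C)c1c(C#N)c2c(N)ncnc2n1C` carries a dimethylamino group on its core. For the measured compounds named here, in an assay on isolated protein for binding affinity to Leucine-rich repeat serine/threonine-protein kinase 2 (Homo sapiens), read by TR-FRET and LanthaScreen, with a stated time of 2 h (a lower number here means a stronger inhibitor, a higher number a weaker inhibitor), compound 2 gives 111 nM, the highest number among the three measured so far. Compound 1 `C[C@@H]1CCCN1c1c(C#N)c2c(N)nc(Nc3ccn(C)n3)cc2n1C` gives 6 nM in this assay, and compound 3 `Cc1nn(C)cc1Nc1nc(N)c2c(C#N)c(N3CCC[C@H]3C)n(C)c2n1` gives 1 nM; both numbers lie beyond the scatter below that of compound 2, but each of these two compounds differs from compound 2 in more than one place, so no single step can be read from them.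

Compound 4 `Cn1c(N2CCCC2)c(C#N)c2c(N)ncnc21` has not been measured. It differs from compound 2 in one place: pyrrolidin-1-yl in place of dimethylamino on an aromatic carbon. Going by the values given here, no measured pair shows this change on its own. The expectation therefore rests on compound 1 at 6 nM and compound 3 at 1 nM, which carry a ring at the same place but also other groups, so only a modest step toward a lower number is expected, not a large one. The expected step is a 2.2-fold lower number from compound 2 to compound 4 (0.35 log units; beyond the scatter). For compound 4 the estimate in this assay is 50 nM, with a range from 15 nM to 160 nM.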

Compound 4, inhibition constant: 41 nM
Estimate against measurement, compound 4: 1.2-fold (0.09 log units) above; measured number inside the range.
By their numbers in this assay, from the lowest: compound 3; then compound 1; then compound 4; then compound 2.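

Pyrrolidin-1-yl in place of dimethylamino on this aromatic carbon, read here on its own for the first time, gives in this assay a 2.7-fold lower number from compound 2 to compound 4 (0.43 log units; beyond the scatter), so closing the two methyl groups of the amine into a five-membered non-aromatic ring is tolerated and yields a modest gain on the shared core. The ring alone leaves compound 4 at 41 nM, and the steps from it to compound 1 and compound 3 cannot be read, as those compounds differ from it in more than one place. No measurement available here accounts for the step.

From the compounds shown here alone, it remains open whether a smaller azetidin-1-yl or a larger piperidin-1-yl at this carbon would carry the trend further or reverse it. The separate contribution of a methyl group on the pyrrolidine ring also remains unresolved.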